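This account rests on a few compounds, and the source may have more. Where it says the series, first, only, none or still open, it means among the compounds named here.

Measured so far:
Compound 1 `N#CCn1c(-c2ccco2)nc2ccccc21`: 88100 nM
Compound 2 `N=C(Cn1c(-c2ccco2)nc2ccccc21)NN`: 53100 nM
Compound 3 `N#C/C(=C1/SCC(=O)N1c1ccccc1)n1c(-c2ccco2)nc2ccccc21`: 55900 nM

All three were tested in a functional assay on MCF7 cells (Homo sapiens) for cytotoxicity, read by sulforhodamine B assay, with a stated time of 48 h (on this read-out lower numbers stand for stronger inhibition and higher numbers for weaker inhibition), and compound 1 is not separated from the other two by more than the usual scatter of repeated measurements. Compound 4 `N=C1N=C(n2c(-c3ccco3)nc3ccccc32)CN1` has not yet been measured. It differs from compound 1 on an aromatic nitrogen, where the cyanomethyl group leaves: a group of 6 heavy atoms (3 carbon, 3 nitrogen; one five-membered non-aromatic ring with 2 hetero atoms) in place of a group of 3 heavy atoms (2 carbon, 1 nitrogen; no ring), on an aromatic nitrogen.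

One measured step changes the group at this place, a 1.7-fold lower number from compound 1 to compound 2 (0.22 log units; within the scatter). Compound 3 also differs from compound 1 on that nitrogen, and compound 3 gives 55900 nM, again within the scatter of compound 1. Going by the values given here, no measured compound carries the ring that enters in compound 4, so this evidence is indirect. Resting on compound 2 and compound 3, no step beyond the scatter is expected in this assay.

For compound 4 the estimated value is 58000 nM, with an expected range from 25000 nM to 120000 nM. That estimate means an expected 1.5-fold lower number from compound 1 to compound 4 (0.18 log units; within the scatter).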

Compound 4, half-maximal inhibitory concentration: 93000 nM
For compound 4 the middle estimate is 1.6-fold (0.21 log units) below the measured one, within the range that was stated.
By their numbers in this assay, from the lowest: compounds 2, 3, 1 and 4 (each within the scatter of the next).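

With a five-membered non-aromatic ring with 2 hetero atoms on the aromatic nitrogen in place of cyanomethyl, this assay shows a 1.1-fold higher number from compound 1 to compound 4 (0.02 log units; within the scatter), so this ring, which brings 2 hydrogen-bond donors where cyanomethyl has none, does not separate compound 4 from compound 1. Closing the open group of compound 2 into this ring likewise gives a 1.8-fold higher number from compound 2 to compound 4 (0.24 log units; within the scatter), and that pair spans the lowest and highest of the four numbers, so all four compounds lie within the scatter of one another and this position has so far shown no step beyond it. No measurement among the data bears on why these groups give such similar numbers.

As far as these compounds go, it remains open whether a carboxylic acid or a longer alkyl chain on this nitrogen would move the number beyond the scatter. From the compounds shown here alone, it also remains open whether any group other than furan-2-yl on the neighbouring ring atom would do so.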